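Swapping a cyclohexylamine ether for a piperidinyloxyethyl chain

The source may report more compounds than this note shows. Statements on the series, on what has been measured and on what is new or still open speak of the compounds shown alone.

In an ADME assay on microsomes from liver (Homo sapiens) for metabolic stability, read by LC-MS, tested at 1 uM (on this read-out higher numbers stand for fast clearance and lower numbers for slow clearance), compound 1, `CC(C)(O)CN1CCC(Oc2ccc([C@H]3CC[C@]4(CC3)OOC3(O4)C4CC5CC(C4)CC3C5)cc2)CC1`, gives 18 mL.min-1.g-1. Compound 3, `CC(C)(O)CNCCCOc1ccc([C@H]2CC[C@]3(CC2)OOC2(O3)C3CC4CC(C3)CC2C4)cc1`, gives 8 mL.min-1.g-1 in this assay. For compound 2, `N[C@H]1CC[C@@H](Oc2ccc([C@H]3CC[C@]4(CC3)OOC3(O4)C4CC5CC(C4)CC3C5)cc2)CC1`, this assay reports only a limit, < 7 mL.min-1.g-1. Compound 2 therefore stands at the floor of the numbers shown, the point described by the limit of < 7 mL.min-1.g-1 in this assay, at which 1 of the 3 values shown sits.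

Compound 4, `c1cc([C@H]2CC[C@]3(CC2)OOC2(O3)C3CC4CC(C3)CC2C4)ccc1OCCOC1CCNCC1`, has not yet been measured. Relative to compound 2 the change is 2-((piperidin-4-yl)oxy)ethyl in place of 4-aminocyclohexyl on an oxygen on an aromatic ring. Within the data shown here, two measured steps bear on it. Taking away the piperidine ring that carries a 2-hydroxy-2-methylpropyl group gave an at least 2.5-fold lower number from compound 1 to compound 2 (0.41 log units; beyond the scatter), a change beyond the scatter toward slower clearance. Opening that ring into a chain with a secondary amine gave a 2.3-fold lower number from compound 1 to compound 3 (0.35 log units; beyond the scatter), and between the two low compounds the difference is an at least 1.1-fold higher number from compound 2 to compound 3 (0.05 log units; that floor lies within the scatter), which stays within the scatter. Compound 4 returns a ring nitrogen as a secondary amine within the 2-((piperidin-4-yl)oxy)ethyl group, so only a small rise from the floor, if any, is expected. The expected step is an at least 1.2-fold higher number from compound 2 to compound 4 (0.10 log units; that floor lies within the scatter). For compound 4 the estimate in this assay is 9 mL.min-1.g-1, between 5 mL.min-1.g-1 and 17 mL.min-1.g-1.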

Compound 4, intrinsic clearance in microsomes: < 7 mL.min-1.g-1
Compound 4: no number, only a limit; the forecaster's own chance of this, stated with the estimate: 35%; middle value at least 1.2-fold (0.10 log units) from the limit.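

In this assay compound 4 joins compound 2 at the bottom of the scale, and neither gives a number, only a limit: the limit of < 7 mL.min-1.g-1 in this assay, at which 2 of the 4 values shown sit.

The new result shows that this position on the oxygen on the aromatic ring accepts a larger group with an added ether oxygen and a ring that carries a nitrogen, and the reading still stays at that limit. Compared with compound 1 the change is clear, with an at least 2.5-fold lower number from compound 1 to compound 4 (0.41 log units; beyond the scatter), so compound 4 is a third compound, after compound 2 and compound 3, that reads lower than compound 1. Compared with compound 3 the result is an at least 1.1-fold lower number from compound 3 to compound 4 (0.05 log units; that floor lies within the scatter), and because that floor lies within the scatter, no order between the two can be claimed; the step between the two limits cannot be read at all.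

As far as these compounds go, the true values of compound 2 and compound 4 stay unknown, so the carbon-only ring and the ring with a nitrogen cannot be ranked against each other. From the compounds shown here alone, it also remains open whether a longer chain or a carboxylic acid in place of 2-((piperidin-4-yl)oxy)ethyl on that oxygen would read as low.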